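Methoxy in place of methyl on the fused ring

This account rests on a few compounds, and the source may have more. Where it says the series, first, only, none or still open, it means among the compounds named here.

Measured so far:
compound 1 `O=C(Nc1ccc(-n2ncc3c(F)cccc32)cc1)Nc1ccc(Cl)c(C(F)(F)F)c1`: 3800 nM
compound 2 `Cc1cccc2c1cnn2-c1ccc(NC(=O)Nc2ccc(Cl)c(C(F)(F)F)c2)cc1`: 5500 nM

Within the data shown here, in a functional assay on A549 cells (Homo sapiens) for cytotoxicity, read by MTT assay, with a stated time of 72 h (a higher number here means a weaker inhibitor, a lower number a stronger inhibitor), compound 2 gives the higher of the two numbers, but the only neighbour, compound 1, sits within the scatter: a 1.4-fold higher number from compound 1 to compound 2 (0.16 log units; within the scatter). Compound 3 `COc1cccc2c1cnn2-c1ccc(NC(=O)Nc2ccc(Cl)c(C(F)(F)F)c2)cc1` differs from compound 2 by methoxy in place of methyl on an aromatic carbon. Among the measured compounds shown here, the single measured step bearing on this change is the exchange of substituents at the same aromatic carbon, and it stayed within the scatter, so no shift beyond the scatter is expected in this assay. Compound 3 is therefore estimated at 5000 nM, with a range of 2500 nM to 10000 nM, an expected step of a 1.1-fold lower number from compound 2 to compound 3 (0.04 log units; within the scatter).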

Compound 3, half-maximal inhibitory concentration: 3700 nM
The estimate for compound 3 lay 1.4-fold (0.13 log units) above the measured number; measured number inside the range.
By their numbers in this assay, from the lowest: compounds 3, 1 and 2 (each within the scatter of the next).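

In this assay methoxy at this aromatic carbon gives a 1.5-fold lower number from compound 2 to compound 3 (0.17 log units; within the scatter) and, against fluoro, a 1.0-fold lower number from compound 1 to compound 3 (0.01 log units; within the scatter). Methoxy, which brings a hydrogen-bond acceptor that methyl lacks, therefore joins fluoro and methyl within the scatter of one another, so this change shifts nothing readable and the position has now tolerated three different substituents in this assay. No evidence on the reason for this is at hand. Open, on these data alone, is whether an amine, a carboxylic acid or a longer chain such as ethoxy at this carbon would give a step beyond the scatter.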